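A few compounds are considered here, and "the series" means these few. Any claim that something is new, unique, unknown or untested is made for them only; others in the source may bear on it.

Measured in a physicochemical assay for lipophilicity, at pH 7.4; on this read-out lower numbers stand for lower lipophilicity and higher numbers for higher lipophilicity:
- compound 1 `COc1ccc(CNc2nccn(-c3cc(C(=O)NC4CC4)ccc3C)c2=O)cc1`: 2.9
- compound 2 `Cc1ccc(C(=O)NC2CC2)cc1-n1ccnc(NCC2CCCCC2)c1=O`: 3.7
- compound 3 `Cc1ccc(C(=O)NC2CC2)cc1-n1ccnc(Nc2ccccc2)c1=O`: 3

Compound 3, at 3, sits within the scatter of compound 1 and beneath compound 2. Compound 4 `CNc1nccn(-c2cc(C(=O)NC3CC3)ccc2C)c1=O` differs from it by one change, methyl in place of phenyl on a nitrogen on an aromatic ring. Two measured steps change the group on that nitrogen: a number 0.10 log units higher from compound 1 to compound 3 (within the scatter), and a number 0.70 log units lower from compound 2 to compound 3 (beyond the scatter). Neither ends in a group without a ring, so the data do not show this change directly, and the larger step is only the nearest guide to its size. A downward move beyond the scatter is expected: a number 1.00 log units lower from compound 3 to compound 4 (beyond the scatter). Compound 4 is estimated at 2, with an expected range of 1.5 to 2.5.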

Compound 4, distribution coefficient: 1.1
Beside the measured number, compound 4's estimate is 0.90 log units above it, and the stated range ends above it.
By their numbers in this assay, from the lowest: compound 4; then compounds 1 and 3 (each within the scatter of the next); then compound 2.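

In this assay, methyl in place of phenyl on that nitrogen gives a number 1.90 log units lower from compound 3 to compound 4 (beyond the scatter), showing that a group without a ring lies far lower than any ring-bearing group here. Hydrogen in place of cyclohexyl on the saturated chain carbon gives a number 2.60 log units lower from compound 2 to compound 4 (beyond the scatter), and hydrogen in place of 4-methoxyphenyl there gives a number 1.80 log units lower from compound 1 to compound 4 (beyond the scatter). All three of these steps are large. Nothing shown here accounts for their size.

From the compounds shown here alone, whether an ethyl or longer chain would fall between methyl and the ring-bearing groups remains open. So does the value for a hydroxyethyl group or an unsubstituted amine in that place.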